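The source may hold more compounds than are shown below. What is called first, only, known or untested is meant among the compounds shown, and "the series" means these compounds.

Working notes on the carbamate series.

Three compounds carry numbers in an ADME assay on BEAS-2B cells (Homo sapiens) for cytotoxicity, read by MTT assay, with a stated time of 72 h; a lower number here means a stronger inhibitor of growth, a higher number a weaker inhibitor of growth. Compound 1 `COc1ccc(OC(=O)Nc2ccc([Se]C#N)cc2)cc1` gives 25200 nM in this assay. Compound 2 `CCCCOC(=O)Nc1ccc([Se]C#N)cc1` gives 5000 nM. Compound 3 `N#C[Se]c1ccc(NC(=O)Oc2ccc(Cl)cc2)cc1` gives 9300 nM. Compound 2 holds the lowest of the three numbers; compound 3 sits within the scatter of it, while compound 1 lies beyond it. Among the measured compounds shown here, the single one-place step measured so far lies on the aromatic carbon: a 2.7-fold lower number from compound 1 to compound 3 (0.43 log units; beyond the scatter), a modest step on the aryl side of the carbamate.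

Compound 4 `CCOC(=O)Nc1ccc([Se]C#N)cc1` is not yet measured. It differs from compound 2 by hydrogen in place of ethyl on a saturated chain carbon, two bonds along the chain from an oxygen next to a carbonyl group. For the measured compounds named here, no measured step touches the chain on the oxygen side of the carbonyl, so nothing recorded bears directly on this change; the aromatic step from compound 1 to compound 3 is the only guide to the scale of change in this assay, and it is modest. The expectation is therefore a step of a 1.4-fold higher number from compound 2 to compound 4 (0.15 log units; within the scatter), not beyond the scatter. Compound 4 is estimated at 7000 nM, in a range from 3000 nM to 20000 nM.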

Compound 4, concentration for 50% growth inhibition: 21700 nM
Compound 4: middle estimate off by 3.1-fold (0.49 log units), on the low side; measured number above the stated range.
By their numbers in this assay, from the lowest: compounds 2 and 3 (each within the scatter of the next); then compounds 4 and 1 (each within the scatter of the next).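

In this assay the chain on the oxygen side of the carbonyl now has its first measured step: butyl to ethyl gives a 4.3-fold higher number from compound 2 to compound 4 (0.64 log units; beyond the scatter) and so lies beyond the scatter. This position is therefore not silent in this assay, and here the shorter chain carries the higher number. The change removes only the two carbons of the ethyl named in the step, so even a small trim of this chain can register on this read-out. No measured evidence bears on why the number moves with this change.

Two chain lengths alone define no trend along the chain. As far as these compounds go, how a methyl or propyl chain, a longer chain such as hexyl, or an amine at the end of the butyl chain would read remains open.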